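This account rests on a few compounds, and the source may have more. Where it says the series, first, only, none or still open, it means among the compounds named here.

Compound 1 `Fc1ccc(CSc2nnc(-c3ccc4c(c3)OCCO4)o2)cc1`: 38000 nM
Compound 2 `O=[N+]([O-])c1cccc(CSc2nnc(-c3ccc4c(c3)OCCO4)o2)c1`: 38300 nM

Of the compounds shown here, two have been measured in a functional assay on HepG2 cells (Homo sapiens) for antiproliferative activity, read by MTT assay, with a stated time of 48 h; on this read-out lower numbers stand for stronger inhibition and higher numbers for weaker inhibition. Compound 1 has the lower of the two numbers, but compound 2 sits at a value that is within the usual scatter of repeated measurements, so the two cannot be told apart on these data. Both share the same core, and both are weakly active on this read-out.

Compound 3 `Clc1ccccc1CSc1nnc(-c2ccc3c(c2)OCCO3)o1` has not yet been measured. It differs from compound 1 in one place: 2-chlorophenyl in place of 4-fluorophenyl on a saturated chain carbon bound to a sulfur. The group that leaves and the group that enters each count seven heavy atoms and one six-membered aromatic ring of carbon only, with no donors or acceptors.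

Among the compounds with values here, with no measured step to draw on, the expectation for compound 3 in this assay is a number close to that of compound 1, with no change beyond the scatter in either direction. Compound 3 is thus estimated at 35000 nM, in a range from 12000 nM to 100000 nM, which means an expected step of a 1.1-fold lower number from compound 1 to compound 3 (0.04 log units; within the scatter).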

Compound 3, half-maximal inhibitory concentration: 22600 nM
Beside the measured number, compound 3's estimate is 1.5-fold (0.19 log units) above it; measured number inside the range.
By their numbers in this assay, from the lowest: compounds 3, 1 and 2 (each within the scatter of the next).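

In this assay, placing 2-chlorophenyl in place of 4-fluorophenyl on a saturated chain carbon bound to a sulfur gives a 1.7-fold lower number from compound 1 to compound 3 (0.23 log units; within the scatter). This single step shows that this position can accept a change in both the halogen and its place on the aromatic ring without a difference that can be told from repeat-measurement scatter, so the two compounds remain indistinguishable here. Nothing available explains the size of this step.

Because the halogen and its ring place change together, the step cannot show what each change does alone, and 4-chlorophenyl would be needed to separate them. As far as these compounds go, it also remains open whether an amine or a carboxylic acid on the aromatic ring, or a longer chain between that ring and the sulfur, would move the number beyond the scatter.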